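Does Removing a Fluoro Group Change Growth Inhibition?

This account rests on a few compounds, and the source may have more. Where it says the series, first, only, none or still open, it means among the compounds named here.

Compound 1 `COc1cc(OC)cc(-c2ccc(-c3ccc(C(=N)N)c(F)c3)s2)c1`, compound 2 `N=C(N)c1ccc(-c2ccc(-c3ccc(Cl)cc3)s2)cc1F` and compound 3 `N=C(N)c1ccc(-c2ccc(-c3ccc(Cl)cc3)s2)cc1` were each tested in a functional assay on M14 cells (Homo sapiens) for inhibition, read by sulforhodamine B assay, with a stated time of 48 h; on this read-out higher numbers stand for weaker inhibition of growth and lower numbers for stronger inhibition of growth. Compound 1 gives 184 nM, compound 2 gives 179 nM and compound 3 gives 172 nM, and all three numbers lie within the scatter of one another. Compound 2 and compound 3 differ in one place only, (hydrogen in place of fluoro on an aromatic carbon), and this step gave a 1.0-fold lower number from compound 2 to compound 3 (0.02 log units; within the scatter). The difference between the core of compound 1 and the core of compound 2 is not broken down here. Compound 4 `COc1cc(OC)cc(-c2ccc(-c3ccc(C(=N)N)cc3)s2)c1` has not yet been measured. Among the compounds with values here, it differs from compound 1 by hydrogen in place of fluoro on an aromatic carbon, the same change as the one from compound 2 to compound 3, with the surroundings of the place described in the same words. Resting on a 1.0-fold lower number from compound 2 to compound 3 (0.02 log units; within the scatter), the expected step is a 1.1-fold lower number from compound 1 to compound 4 (0.02 log units; within the scatter) in this assay, a step that would stay within the scatter. Compound 4 is therefore expected to give 175 nM, with the estimate running from 100 nM to 320 nM.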

Compound 4, concentration for 50% growth inhibition: 1730 nM
Compound 4: middle estimate off by 9.9-fold (1.00 log units), on the low side; the whole stated range lies below it.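

In this assay, hydrogen in place of fluoro on an aromatic carbon gave a 9.4-fold higher number from compound 1 to compound 4 (0.97 log units; beyond the scatter), whereas on the other core the same change gave a 1.0-fold lower number from compound 2 to compound 3 (0.02 log units; within the scatter). Within the data shown here, the outcome of this change therefore did not carry from one core to the other, and a step read on one of these cores is a poor guide to the step on the other: the same change on two cores in this assay, a 1.0-fold lower number (0.02 log units; within the scatter) from compound 2 to compound 3 and a 9.4-fold higher number (0.97 log units; beyond the scatter) from compound 1 to compound 4, 9.8-fold (0.99 log units) apart, beyond the scatter of two such steps This shows that the core matters, but it rests on only two pairs and does not show which part of the core is responsible, nor why fluoro counts on one core and not on the other.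

The compounds shown leave open whether a methyl group, a hydroxyl group or a nitrile in that place on the core of compound 1 would give a number close to that of compound 1 or to that of compound 4. Among these compounds, they also leave open whether the gap between the cores would remain if only one methoxy group were present on the core of compound 1.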